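Aryl-piperazine variation on a fused bicyclic oxazolone core

The source may hold more compounds than are shown below. What is called first, only, known or untested is meant among the compounds shown, and "the series" means these compounds.

Compound 1, `O=c1oc2cccnc2n1CCCN1CCN(c2ccccc2)CC1`: 15.5 mg/kg
Compound 2, `O=c1oc2cccnc2n1CN1CCN(c2ccc(F)cc2)CC1`: 3.5 mg/kg
Compound 3, `O=c1oc2cccnc2n1CCN1CCCCC1`: > 25 mg/kg

Of the compounds shown here, three sharing one core have been measured in a functional assay on the whole organism with Mus musculus as the target; a lower number here means that less compound is needed, a higher number that more compound is needed for the effect. Compound 2 gives 3.5 mg/kg, the lowest of the two numbers shown; its nearest neighbour, compound 1, gives 15.5 mg/kg, a gap that lies beyond the usual scatter of this assay. Compound 3 returns > 25 mg/kg, which is the limit of > 25 mg/kg in this assay, at which 1 of the 3 values shown sits, and not a number. Among the compounds with values here, no two of the measured compounds differ in a single place, so no measured step can be isolated from them.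

The next compound, compound 4, `COc1ccccc1N1CCN(Cn2c(=O)oc3cccnc32)CC1`, differs from compound 2 in one place: 2-methoxyphenyl in place of 4-fluorophenyl on an amine nitrogen in a ring. The measured compounds carry phenyl, 4-fluorophenyl or no aryl group at all on the ring amine, and none of them carries a methoxy substituent, so the data offer no direct guide to this change. In this assay the step from compound 2 to compound 4 is expected to be small, in either direction or none beyond the scatter, as a 1.3-fold higher number from compound 2 to compound 4 (0.11 log units; within the scatter). Compound 4 is therefore estimated at 4.5 mg/kg, with a plausible range from 1.5 mg/kg to 14 mg/kg.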

Compound 4, dose for half-maximal effect: > 25 mg/kg
Compound 4 was reported as a limit (the forecaster's own chance of this, stated with the estimate: 10%); middle value at least 5.5-fold (0.74 log units) from the limit.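

In this assay, the group on the ring amine proves able to decide the result by itself: 2-methoxyphenyl in place of 4-fluorophenyl, with the rest of compound 2 unchanged, gives an at least 7.1-fold higher number from compound 2 to compound 4 (0.85 log units; beyond the scatter). Within the data shown here, none of the earlier compounds differed in a single place, so this is the first measured step at this position, and it shows that exchanging one aryl group for another here is not a neutral change. The reading for compound 4 is a limit and not a number, so the step has a lower bound but no known size: the limit of > 25 mg/kg in this assay, at which 2 of the 4 values shown sit.

The compounds shown leave open whether the higher number belongs to the methoxy group itself or to where it sits on the phenyl ring; a 4-methoxyphenyl or a 2-fluorophenyl group on the same ring amine would separate the two. From the compounds shown here alone, how a plain phenyl group or a pyridyl group would read in place of 4-fluorophenyl in compound 2 remains open as well.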